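Chloro for Fluoro: a Step Yet to Be Measured

The compounds below may be only part of what the source reports. "The series", "measured", "known", "first", "only" and "open" are said of these compounds alone.

Measured in an assay on isolated protein for inhibition of Myeloperoxidase (Homo sapiens), read by fluorescence, with stated times of 10 min, 30 s and 5 min; on this read-out lower numbers stand for stronger inhibition and higher numbers for weaker inhibition:
Compound 1 `CCNc1nc(OCc2ccccc2)c2nn[nH]c2n1`: 2900 nM
Compound 2 `Nc1nc(OCCc2ccccc2)c2nn[nH]c2n1`: 630 nM
Compound 3 `Nc1nc(OCc2cccc(F)c2)c2nn[nH]c2n1`: 40 nM

Compound 3 stands lowest of the three numbers. Its nearest neighbour is compound 2, whose number is higher by a margin beyond the scatter, and compound 1 lies furthest, also beyond the scatter. For the measured compounds named here, no two measured compounds differ in one place only, so no measured step of a single change is available. Compound 4 `Nc1nc(OCc2cccc(Cl)c2)c2nn[nH]c2n1` differs from compound 3 by chloro in place of fluoro on an aromatic carbon. For this exchange only a small step in this assay is expected, in no sure direction and likely within the scatter. Compound 4 is therefore estimated at 30 nM, in the range 8 nM to 120 nM. That estimate amounts to an expected step of a 1.3-fold lower number from compound 3 to compound 4 (0.12 log units; within the scatter).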

Compound 4, half-maximal inhibitory concentration: 200 nM
Estimate against measurement, compound 4: 6.7-fold (0.82 log units) below; the whole stated range lies below it.
By their numbers in this assay, from the lowest: compound 3; then compound 4; then compound 2; then compound 1.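

In this assay, chloro in place of fluoro on an aromatic carbon of the benzyl-free comparison gives a 5.0-fold higher number from compound 3 to compound 4 (0.70 log units; beyond the scatter) as its measured step, so this place on the ring does not treat the two halogens alike. The earlier compounds shown here, with no pair differing in one place, could not show that a single atom exchanged here moves the number beyond the scatter. Going by these compounds, whether a methoxy, a nitrile or plain hydrogen at this same place would read nearer compound 3 or compound 4 stays open. Nothing shown here accounts for the size of this step.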